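Hydroxyoxetane appended to the pyrazole methyl of compound 1

This account rests on a few compounds, and the source may have more. Where it says the series, first, only, none or still open, it means among the compounds named here.

Compound 1, with the structure `Cc1c(Nc2nc(N)c3c(C#N)c(N4CCC[C@H]4C)n(C)c3n2)cnn1C`, is the starting point of this account. Going by the values given here, in an assay on HEK293 cells for inhibition of Leucine-rich repeat serine/threonine-protein kinase 2 variant G2019S (Homo sapiens), with a stated time of 48 h (on this read-out lower numbers stand for stronger inhibition and higher numbers for weaker inhibition), compound 1 gives 260 nM, the only single number recorded for it, with one further entry that carries no number. A second compound, compound 2 with the structure `Cc1nn(C2CCOC2)cc1Nc1nc(N)c2c(C#N)c(N3CCC[C@H]3C)n(C)c2n1`, carries a different substitution pattern on its pyrazole and is not a single-step neighbour of compound 1; in this assay compound 2 gives 65 nM; 180 nM (2 entries), and the spread across those entries is summarised by the several entries of compound 2 in this assay, 65 nM; 180 nM (2 entries).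

The unmeasured compound 3, with the structure `Cc1c(Nc2nc(N)c3c(C#N)c(N4CCC[C@H]4C)n(C)c3n2)cnn1CC1(O)COC1`, differs from compound 1 by 3-hydroxyoxetan-3-yl in place of hydrogen on a saturated chain carbon bound to an aromatic nitrogen. Among the compounds with values here, no pair of measured compounds shows the effect of such a change, so the expectation rests on compound 1 alone. The authors expect the step from compound 1 to compound 3 in this assay to be small, a 1.3-fold lower number from compound 1 to compound 3 (0.11 log units; within the scatter), not clearly beyond the usual scatter in either direction. On that basis compound 3 is estimated at 200 nM, with a range from 70 nM to 600 nM.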

Compound 3, half-maximal inhibitory concentration: 120 nM
Compound 3: the middle estimate sits 1.7-fold (0.22 log units) above what was measured; the range from low to high includes it.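

Set on the saturated chain carbon bound to an aromatic nitrogen, 3-hydroxyoxetan-3-yl gives a 2.2-fold lower number from compound 1 to compound 3 (0.34 log units; beyond the scatter) in this assay, so this carbon can carry the added group without any loss of inhibition on this read-out. Until now nothing spoke to this place, as compound 1 stood alone and compound 2 was not a single-step neighbour of it. The step is modest and rests on one value for compound 3, and entries for a single compound can lie well apart in this assay: the several entries of compound 2 in this assay, 65 nM; 180 nM (2 entries)

Still open, on these data alone, is whether the hydroxyl or the four-membered ring carries the step, a question that a plain oxetan-3-yl or a hydroxymethyl group at this carbon would help to settle. As far as these compounds go, how an amine, a carboxylic acid or a longer chain would fare at the same place also remains unknown, as does whether the step would carry over to a compound with the pyrazole substitution of compound 2.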